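This account rests on a few compounds, and the source may have more. Where it says the series, first, only, none or still open, it means among the compounds named here.

Compound 1, `CN(c1ccn(C)n1)c1cnc(NCc2c(F)ccc3c2CCO3)c2cn[nH]c(=O)c12`, gives 62 mL.min-1.g-1.
Compound 2, `Cn1cc(-c2cnc(NCc3c(F)ccc4c3CCO4)c3cn[nH]c(=O)c23)cn1`, gives 21 mL.min-1.g-1.
Compound 3, `Cc1nc(CN(C)C)ccc1-c1cnc(NCc2c(F)ccc3c2CCO3)c2cn[nH]c(=O)c12`, gives 13 mL.min-1.g-1.

These numbers come from an ADME assay on microsomes from liver (Homo sapiens) for metabolic stability, read by LC-MS, using NADPH, with stated times of 5 min and 30 min, tested at 1 uM; on this read-out higher numbers stand for fast clearance and lower numbers for slow clearance. Compound 3 has the lowest of the three, but its distance from compound 2 is small: a 1.6-fold lower number from compound 2 to compound 3 (0.21 log units; within the scatter). Against compound 1 the gap is clear: a 4.8-fold lower number from compound 1 to compound 3 (0.68 log units; beyond the scatter).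

Compound 4, `CNC(=O)c1ncc(-c2cnc(NCc3c(F)ccc4c3CCO4)c3cn[nH]c(=O)c23)n1C`, is to be measured in this assay. It differs from compound 3 in one place: 1-methyl-2-(methylcarbamoyl)-1H-imidazol-5-yl in place of 6-((dimethylamino)methyl)-2-methylpyridin-3-yl on an aromatic carbon. All three measured steps exchange the group at this same position. The two steps that started from compound 1, a 3.0-fold lower number from compound 1 to compound 2 (0.47 log units; beyond the scatter) and a 4.8-fold lower number from compound 1 to compound 3 (0.68 log units; beyond the scatter), each replaced methyl(1-methyl-1H-pyrazol-3-yl)amino with an aromatic ring, and both lowered the number. The step that exchanged one aromatic ring for another, a 1.6-fold lower number from compound 2 to compound 3 (0.21 log units; within the scatter), stayed within the scatter. The change to compound 4 is again an exchange of one aromatic ring for another. Given a 1.6-fold lower number from compound 2 to compound 3 (0.21 log units; within the scatter), compound 4 is expected to stay within the scatter of compound 3, with no step beyond it in either direction: a 1.2-fold higher number from compound 3 to compound 4 (0.06 log units; within the scatter). Compound 4 is therefore estimated at 15 mL.min-1.g-1, with a range from 7 mL.min-1.g-1 to 35 mL.min-1.g-1.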

Compound 4, intrinsic clearance in microsomes: 24 mL.min-1.g-1
Beside the measured number, compound 4's estimate is 1.6-fold (0.20 log units) below it; low and high end bracket the measured number.
By their numbers in this assay, from the lowest: compounds 3, 2 and 4 (each within the scatter of the next); then compound 1.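

The 1-methyl-2-(methylcarbamoyl)-1H-imidazol-5-yl group shows that this position tolerates more variety among directly attached aromatic rings than compounds 2 and 3 could show. It brings a five-membered ring, a carbonyl and a hydrogen-bond donor, yet its number stays within the scatter of both the six-membered ring of compound 3 (a 1.8-fold higher number from compound 3 to compound 4 (0.27 log units; within the scatter)) and the simpler 1-methyl-1H-pyrazol-4-yl ring of compound 2 (a 1.1-fold higher number from compound 2 to compound 4 (0.06 log units; within the scatter)), while the gap to the nitrogen-linked group of compound 1 remains (a 2.6-fold lower number from compound 1 to compound 4 (0.41 log units; beyond the scatter)). All three compounds with a directly attached ring now share a lower number than compound 1, though no measurement here explains that gap.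

The compounds shown leave open whether the gain depends on the ring being aromatic, since a saturated ring such as morpholine or a non-ring group such as a carboxylic acid at this carbon could behave differently. They also cannot separate the effect of the linking nitrogen in compound 1 from that of its pyrazole, which a 1-methyl-1H-pyrazol-3-yl ring attached directly, without the methylamino link, would address.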